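The source may hold more compounds than are shown below. What is called first, only, known or untested is meant among the compounds shown, and "the series" means these compounds.

Measured compounds in a physicochemical assay for lipophilicity, read by HPLC, measured as octanol-water partition, with a stated time of 24 h, at pH 7.4; on this read-out lower numbers stand for lower lipophilicity and higher numbers for higher lipophilicity:
- compound 1, `Cc1cc(/C=C/C#N)cc(C)c1Oc1cc(Nc2ccc(C#N)cc2)c(N)cc1C(=O)NN`, gives 2.31
- compound 2, `Cc1cc(/C=C/C#N)cc(C)c1Oc1cc(Nc2ccc(C#N)cc2)c(N)cc1C(=O)NCCC(F)F`, gives 3.58
- compound 3, `COC(=O)c1cc(N)c(Nc2ccc(C#N)cc2)cc1Oc1c(C)cc(/C=C/C#N)cc1C`, gives 4.15

Compound 1 stands lowest of the three numbers in this assay. Its nearest neighbour is compound 2, reached by the step of a number 1.27 log units higher from compound 1 to compound 2 (beyond the scatter), and the furthest is compound 3, reached by the step of a number 1.84 log units higher from compound 1 to compound 3 (beyond the scatter). Between those two measured compounds the step of a number 0.57 log units higher from compound 2 to compound 3 (beyond the scatter) is the smallest of the three.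

The unmeasured compound 4, `Cc1cc(/C=C/C#N)cc(C)c1Oc1cc(Nc2ccc(C#N)cc2)c(N)cc1C(=O)OCCC#N`, differs from compound 1 in one place: 2-cyanoethoxy in place of aminoamino on a carbonyl carbon. For the measured compounds named here, the step most closely related is the one from compound 1 to compound 3, where a methoxy likewise replaced the aminoamino group on the same carbonyl carbon and the number rose by a large amount. Compound 4 carries a 2-cyanoethoxy rather than a methoxy, a longer chain that brings a nitrile with it, so the change is expected to land in the same direction but somewhat short of that step. The author therefore expects a large upward step, a number 1.59 log units higher from compound 1 to compound 4 (beyond the scatter), and estimates compound 4 in this assay at 3.9, within the range 3.3 to 4.5.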

Compound 4, partition coefficient: > 5
Compound 4: a limit, no number (the forecaster's own chance of this, stated with the estimate: 0%); middle value at least 1.10 log units away from the limit.
By their numbers in this assay, from the lowest: compound 1; then compound 2; then compound 3. At a limit, above all of these: compound 4.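

In this assay compound 4 gives > 5, which is a limit of the assay and not a number: the limit of > 5 in this assay, at which 1 of the 4 values shown sits.

On this carbonyl carbon, the change from aminoamino to 2-cyanoethoxy gives a number at least 2.69 log units higher from compound 1 to compound 4 (beyond the scatter), and the change from (3,3-difluoropropyl)amino to 2-cyanoethoxy gives a number at least 1.42 log units higher from compound 2 to compound 4 (beyond the scatter). The earlier compounds shown here had placed methoxy highest among the groups on this carbon, but cyanomethyl in place of hydrogen on the saturated chain carbon bound to an oxygen next to a carbonyl group gives a number at least 0.85 log units higher from compound 3 to compound 4 (beyond the scatter), so here the longer chain carrying a nitrile did not bring the reading down and instead took it past the methoxy compound.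

As far as these compounds go, all three steps end at a limit, so their full sizes stay unknown, and how far 2-cyanoethoxy truly stands above methoxy cannot be read. The compounds shown also leave open how a plain propoxy chain without the nitrile, or a carboxylic acid on the same carbonyl carbon, would read, and so whether the chain length or the nitrile goes with the rise.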